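The source may hold more compounds than are shown below. What is called first, only, known or untested is meant among the compounds shown, and "the series" means these compounds.

In a functional assay on KB cells (Homo sapiens) for inhibition (on this read-out lower numbers stand for stronger inhibition and higher numbers for weaker inhibition), compound 1 `CCOC(=O)c1cn([C@@H]2O[C@H](CO)[C@@H](O)[C@H]2O)c2nnnc(N)c12` gives 80000 nM and compound 2 `Cc1ccc(C(=O)OC[C@H]2O[C@@H](n3cc(C(N)=O)c(C(N)=O)c3N)C[C@@H]2OC(=O)c2ccc(C)cc2)cc1` gives 100000 nM. These two numbers lie within the scatter of each other, so they cannot be ranked. Compound 3 `NC(=S)c1cn([C@@H]2O[C@H](CO)[C@@H](O)[C@H]2O)c2nnnc(N)c12`, not yet measured, keeps the core of compound 1 and changes one group: a group of 3 heavy atoms (1 carbon, 1 nitrogen, 1 sulfur; no ring) in place of a group of 5 heavy atoms (3 carbon, 2 oxygen; no ring), on an aromatic carbon. The ethoxycarbonyl leaves an aromatic carbon of a five-membered aromatic ring with 1 nitrogen, part of a fused or bridged system of two rings. Going by the values given here, no pair of measured compounds differs in one place only, so the data give no direct read on this change. With compound 1 at 80000 nM, there is ample room toward lower numbers on this read-out. A sizeable move toward stronger inhibition in this assay is expected, though a result within the scatter cannot be excluded. The estimated change is a 16-fold lower number from compound 1 to compound 3 (1.20 log units; beyond the scatter). For compound 3 the estimated value is 5000 nM, with an expected range from 300 nM to 80000 nM.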

Compound 3, half-maximal inhibitory concentration: 2000 nM
Compound 3: the middle estimate sits 2.5-fold (0.40 log units) above what was measured, and the stated range covers the measured number.
By their numbers in this assay, from the lowest: compound 3; then compounds 1 and 2 (each within the scatter of the next).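

In this assay, the aromatic carbon two ring bonds from the ring nitrogen proves sensitive to its substituent: on the core of compound 1, the group of 3 heavy atoms in place of ethoxycarbonyl gives a 40-fold lower number from compound 1 to compound 3 (1.60 log units; beyond the scatter). This lifts the series clear of the scatter that left compounds 1 and 2 unranked. The step is one swap but several counted changes at once, since the entering group is smaller, carries sulfur and nitrogen instead of two oxygens, and has 1 hydrogen-bond donor where ethoxycarbonyl has 0, so this single pair cannot assign the gain to any one of them. No measurement accompanies the step that would account for its size.

The compounds shown leave open whether the sulfur matters, as they include no plain carboxamide, nitrile or carboxylic acid on this carbon of the core of compound 1. Also open, as far as these compounds go, is how far the gain extends to a larger group on the same atom, such as an N-methyl or N-ethyl thiocarboxamide, and whether it holds when other parts of the core change.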